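Piperidinylmethoxy for Aminopiperidinyl on a Shared Oxadiazole Core

The source may hold more compounds than are shown below. What is called first, only, known or untested is meant among the compounds shown, and "the series" means these compounds.

Three compounds built on one shared core are considered. Compound 1 `CNCCCNc1nnc(-c2cn3ncnc(Nc4cc(C(=O)NC5CC5)c(F)cc4F)c3c2C(C)C)o1` was tested in a functional assay on HUVEC cells (Homo sapiens) for antiproliferative activity (on this read-out higher numbers stand for weaker inhibition and lower numbers for stronger inhibition), where compound 1 gives 62 nM. Compound 2 `CC(C)c1c(-c2nnc(N3CCC(N)CC3)o2)cn2ncnc(Nc3cc(C(=O)NC4CC4)c(F)cc3F)c12` is recorded in this assay as "not determined" (no result reported); no result was reported for it, so nothing can be said of where it lies against compound 1. Compound 3 `CC(C)c1c(-c2nnc(OCC3CCNCC3)o2)cn2ncnc(Nc3cc(C(=O)NC4CC4)c(F)cc3F)c12` has not yet been measured in this assay. It differs from compound 2 in one place: (piperidin-4-yl)methoxy in place of 4-aminopiperidin-1-yl on an aromatic carbon. Going by the values given here, with no value for compound 2, no step from compound 2 to compound 3 can be computed, and the size and direction of any shift are unknown; the only anchor is the value of compound 1. Compound 3 is expected to give about 80 nM in this assay, within a range from 20 nM to 320 nM, because compound 1 gives 62 nM with a comparable amine-bearing side chain on the same core.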

Compound 3, half-maximal inhibitory concentration: 25 nM
Estimate against measurement, compound 3: 3.2-fold (0.51 log units) above; low and high end bracket the measured number.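

In this assay, (piperidin-4-yl)methoxy in place of (3-(methylamino)propyl)amino on this aromatic carbon of the five-membered ring gives a 2.5-fold lower number from compound 1 to compound 3 (0.39 log units; beyond the scatter), so this position can carry a six-membered non-aromatic ring on an oxygen-containing link with inhibition kept and modestly stronger. Compound 2 has no reported value, so the exchange of 4-aminopiperidin-1-yl for (piperidin-4-yl)methoxy cannot be read. Nothing measured here accounts for the shift.

The compounds shown leave open whether the ring or the oxygen goes with the lower number, since compound 1 and compound 3 differ in both, and (piperidin-4-yl)methylamino would separate the two. Also open, as far as these compounds go, is whether the ring amine matters, which a cyclohexylmethoxy group in the same place would address.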